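A few compounds are considered here, and "the series" means these few. Any claim that something is new, unique, unknown or untested is made for them only; others in the source may bear on it.

Compound 3 `O=C(c1oc(C(F)(F)F)nc1-c1ccc(F)cc1)N1CCN(c2cccc(Cl)c2)CC1` carries a trifluoromethyl group on the shared core together with a 4-fluorophenyl group. In a functional assay on HL-60 cells (Homo sapiens) for inhibition, read by MTT assay, with a stated time of 72 h (a lower number here means a stronger inhibitor, a higher number a weaker inhibitor), compound 3 gives "not active" (no number reported), so no number stands for it. Compound 4 `CCc1nc(-c2ccc(F)cc2)c(C(=O)N2CCN(c3cccc(Cl)c3)CC2)o1` differs from it in one place: ethyl in place of trifluoromethyl on an aromatic carbon.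

The other two compounds keep the ethyl group of compound 4 and vary the aryl group instead. Compound 1 `CCc1nc(-c2ccc(OC)cc2)c(C(=O)N2CCN(c3cccc(Cl)c3)CC2)o1` gives > 1000 nM in this assay, which is a limit; this is the same limit at which one of the three values sits (the limit of > 1000 nM in this assay, at which 1 of the 3 values shown sits). Compound 2 `CCc1nc(-c2ccccc2Cl)c(C(=O)N2CCN(c3cccc(Cl)c3)CC2)o1` gives 98.9 nM. Going by the values given here, the only measured step, an at least 10-fold lower number from compound 1 to compound 2 (1.00 log units; beyond the scatter), concerns 2-chlorophenyl in place of 4-methoxyphenyl on an aromatic carbon and does not touch the trifluoromethyl-to-ethyl change, so no measured step bears directly on the step to compound 4. With compound 3 reported as not active, the expectation for compound 4 is weak, near the limit of this assay, with a wide range. Compound 4 is therefore expected to give about 2000 nM, between 300 nM and 10000 nM.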

Compound 4, half-maximal inhibitory concentration: 169 nM
Compound 4: the middle estimate sits 12-fold (1.07 log units) above what was measured; the measured number lies below the stated range.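

In this assay compound 4 gives 169 nM, whereas compound 3, which carries trifluoromethyl in place of ethyl on the same aromatic carbon, gives "not active" (no number reported), so this one change separates a measurable value from none, although the step between the two cannot be read as a size. With ethyl kept, the change of aryl group gives a 1.7-fold higher number from compound 2 to compound 4 (0.23 log units; within the scatter), so 4-fluorophenyl and 2-chlorophenyl cannot be told apart here, and the change of para-free substituent gives an at least 5.9-fold lower number from compound 1 to compound 4 (0.77 log units; beyond the scatter). The value of compound 1 is a limit, so that second step is a bound and not a size: the limit of > 1000 nM in this assay, at which 1 of the 4 values shown sits.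

Only ethyl and trifluoromethyl are shown on this aromatic carbon, so it remains open how a methyl group, a longer chain or an amine would read there. Going by these compounds, it also remains open whether trifluoromethyl would give a number alongside 2-chlorophenyl instead of 4-fluorophenyl.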